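The source may hold more compounds than are shown below. What is called first, only, known or untested is meant among the compounds shown, and "the series" means these compounds.

Working notes on the series. The three measured compounds share one core and differ in the aryl on the carbon with a double bond to nitrogen. In a functional assay on WM 266-4 cells (Homo sapiens) for antiproliferative activity, read by MTT assay, with a stated time of 48 h (on this read-out lower numbers stand for stronger inhibition of growth and higher numbers for weaker inhibition of growth), compound 1 `S=C(Nc1ccccc1)N1N=C(c2ccc(Br)cc2)CC1c1ccc2c(c1)OCCO2` gives 870 nM, and compound 2 `Cc1ccc(C2=NN(C(=S)Nc3ccccc3)C(c3ccc4c(c3)OCCO4)C2)cc1` gives 10300 nM. Compound 3 `S=C(Nc1ccccc1)N1N=C(c2ccccc2Br)CC1c1ccc2c(c1)OCCO2` reaches only a limit of this assay, > 200000 nM, as noted under (the limit of > 200000 nM in this assay, at which 1 of the 3 values shown sits). The two measured steps that lead to it, an at least 220-fold higher number from compound 1 to compound 3 (2.36 log units; beyond the scatter) and an at least 19-fold higher number from compound 2 to compound 3 (1.28 log units; beyond the scatter), are both large. Compound 4 `S=C(Nc1ccccc1)N1N=C(c2ccc(Cl)c(Cl)c2)CC1c1ccc2c(c1)OCCO2` differs from compound 3 by 3,4-dichlorophenyl in place of 2-bromophenyl on a carbon with a double bond to nitrogen. Since both steps onto 2-bromophenyl raised the number far beyond the scatter, moving away from it to 3,4-dichlorophenyl is expected to lower the number substantially, so for compound 4 the expected step is an at least 100-fold lower number from compound 3 to compound 4 (2.00 log units; beyond the scatter). Compound 4 is estimated at 2000 nM, with a range from 300 nM to 15000 nM.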

Compound 4, concentration for 50% growth inhibition: 58700 nM
Compound 4: the middle estimate sits 29-fold (1.47 log units) below what was measured, outside the stated range (above it).
By their numbers in this assay, from the lowest: compound 1; then compound 2; then compound 4. At a limit, above all of these: compound 3.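

At this position, 3,4-dichlorophenyl restores a measurable number compared with 2-bromophenyl, an at least 3.4-fold lower number from compound 3 to compound 4 (0.53 log units; beyond the scatter). Even so, two halogens on the aryl do not match 4-methylphenyl, a 5.7-fold higher number from compound 2 to compound 4 (0.76 log units; beyond the scatter), or 4-bromophenyl, a 67-fold higher number from compound 1 to compound 4 (1.83 log units; beyond the scatter), so a halogen on this aryl does not by itself give the low number of compound 1. Compound 3 stands at a limit, so the first step is only a bound: the limit of > 200000 nM in this assay, at which 1 of the 4 values shown sits. Still open, from the compounds shown here alone, is how an aryl carrying an amine or a carboxylic acid would read in this assay.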